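Tertiary amide variation at the carboxamide of the shared core

This account rests on a few compounds, and the source may have more. Where it says the series, first, only, none or still open, it means among the compounds named here.

Of the compounds shown here, two on the shared core have been measured in an assay on cells for inhibition of Palmitoleoyl-protein carboxylesterase NOTUM variant C330S (Homo sapiens), read by fluorescence, with a stated time of 40 min (on this read-out higher numbers stand for weaker inhibition and lower numbers for stronger inhibition), so far. Compound 1 `COCCNC(=O)C1CCN(c2ccc(Cl)c(C(F)(F)F)c2)C1` carries a (2-methoxyethyl)amino on the carbonyl carbon, and in this assay compound 1 gives 3500 nM. Compound 2 `CN(C)C(=O)C1CCN(c2ccc(Cl)c(C(F)(F)F)c2)C1` carries dimethylamino on that carbonyl carbon, and in this assay compound 2 gives 1200 nM. Going by the values given here, the one step between them reads a 2.9-fold lower number from compound 1 to compound 2 (0.46 log units; beyond the scatter). Compound 2 thus stands at the lowest of the two numbers, with compound 1 the nearest neighbour at a modestly higher number.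

Compound 3 `O=C(C1CCN(c2ccc(Cl)c(C(F)(F)F)c2)C1)N1CCCC1` has not yet been measured. The change from compound 2 is pyrrolidin-1-yl in place of dimethylamino on a carbonyl carbon. Among the compounds with values here, only the step from compound 1 to compound 2 bears on the amide, and it exchanged a secondary amide for a tertiary one with a modest drop in the number. The change to compound 3 keeps a tertiary amide and only closes the two methyl carbons into a five-membered ring, so the expected step is one within the scatter, a 1.3-fold lower number from compound 2 to compound 3 (0.12 log units; within the scatter). Compound 3 is therefore estimated at 900 nM, with an expected range from 350 nM to 2500 nM.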

Compound 3, half-maximal inhibitory concentration: 410 nM
Estimate against measurement, compound 3: 2.2-fold (0.34 log units) above, and the stated range covers the measured number.
By their numbers in this assay, from the lowest: compound 3; then compound 2; then compound 1.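

In this assay, closing the two methyl groups of dimethylamino into pyrrolidin-1-yl on the carbonyl carbon gives a 2.9-fold lower number from compound 2 to compound 3 (0.47 log units; beyond the scatter) and so is not a silent change: two tertiary amides on the shared core, with no hydrogen-bond donor or acceptor count changed in the group, still read apart. Across the three compounds, the group on this carbonyl carbon moves the number further than either earlier comparison alone could show, with an 8.5-fold lower number from compound 1 to compound 3 (0.93 log units; beyond the scatter) as the widest span so far, and compound 3 holds the lowest number, its steps to both other compounds being beyond the scatter. No measurement here explains the difference between the ring and the open-chain group.

As far as these compounds go, whether the ring itself or simply the larger carbon count goes with the lower number stays open, and diethylamino on the same carbonyl carbon would separate the two. Also open, from the compounds shown here alone, is how far the ring can change, as with piperidin-1-yl, azetidin-1-yl or a pyrrolidin-1-yl bearing a hydroxyl group.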